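Cyano for Methyl on the Distant Aryl Ring

This account rests on a few compounds, and the source may have more. Where it says the series, first, only, none or still open, it means among the compounds named here.

Among the measured compounds shown here, compound 1 `Cc1ccc(-c2cs/c(=N/NC(=O)CSc3nnnn3-c3ccccc3)n2-c2ccccc2)cc1` is the stronger of the two compounds measured so far in a functional assay on C6 cells (Rattus norvegicus) for cytotoxicity, read by MTT assay, with a stated time of 24 h, tested at 200 ug/mL; a higher number here means a weaker effect of the compound at the concentration tested, a lower number a stronger effect: compound 1 gives 22.2%, the lowest of the two numbers in hand. Its nearest neighbour is compound 2 `Cc1ccc(-c2cs/c(=N/NC(=O)CSc3nnnn3C)n2-c2ccccc2)cc1`, in which a methyl replaces a phenyl on an aromatic nitrogen; in this assay compound 2 gives 39.7%, and the step of a number 17.5 percentage points higher from compound 1 to compound 2 (beyond the scatter) lies beyond the scatter. Compound 3 `N#Cc1ccc(-c2cs/c(=N/NC(=O)CSc3nnnn3-c3ccccc3)n2-c2ccccc2)cc1` has not yet been tested. It differs from compound 1 at another place: cyano in place of methyl on an aromatic carbon. For the measured compounds named here, the one measured step concerns the group on an aromatic nitrogen, not the group on the six-membered aromatic ring of carbon only, so no measured step bears on this change, and its size and direction are open. With the rest of the molecule unchanged, the expected outcome is a step in this assay of about a number 3.8 percentage points higher from compound 1 to compound 3 (within the scatter), which is expected to stay within the scatter. Compound 3 is therefore estimated at 26% in this assay, with a likely range from 10% to 45%.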

Compound 3, a percentage reported as activity, at one concentration (the size of the read-out at that concentration, not a potency): 54%
For compound 3 the middle estimate is 28 percentage points below the measured one; the measured number lies above the stated range.
By their numbers in this assay, from the lowest: compound 1; then compound 2; then compound 3.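

Going from 4-methylphenyl to 4-cyanophenyl in this assay gives a number 31.8 percentage points higher from compound 1 to compound 3 (beyond the scatter), so this place, on an aromatic carbon of a six-membered aromatic ring of carbon only, clearly matters for the effect at the tested concentration. The earlier step concerned only the group on an aromatic nitrogen, and this result adds a second place where swapping a single group moves the read-out beyond the usual scatter, here toward a weaker effect, with the methyl compound the stronger of the pair. No measurement at hand bears on the cause of this step.

Among the compounds shown here, with only one pair at this place, it stays open whether the weaker effect belongs to cyano alone or would also appear with other groups here, such as an amine, a carboxylic acid, a chlorine atom or a longer chain like ethyl. Also open, as far as these compounds go, is whether the same swap would act in the same way on compound 2, which carries a methyl on the aromatic nitrogen where compound 1 and compound 3 carry a phenyl.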